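Trifluoromethoxy to Methoxy: What to Expect for Compound 4

A few compounds are considered here, and "the series" means these few. Any claim that something is new, unique, unknown or untested is made for them only; others in the source may bear on it.

Of the compounds shown here, three sharing one core have been measured in an assay on isolated protein with Bile acid receptor (Homo sapiens) as the target; on this read-out higher numbers stand for an effect only at larger amounts of compound and lower numbers for an effect already at smaller amounts. Compound 1 `COC(=O)/C=C/c1cccc(N(Cc2ccc(/C=C/c3cccc(F)c3)cc2)C(=O)C(C)C)c1` gives 71 nM in this assay, compound 2 `COC(=O)/C=C/c1cccc(N(Cc2ccc(-c3cccc(Cl)c3)cc2)C(=O)C(C)C)c1` gives 77 nM, and compound 3 `COC(=O)/C=C/c1cccc(N(Cc2ccc(-c3cccc(OC(F)(F)F)c3)cc2)C(=O)C(C)C)c1` gives 247 nM, the highest of the three numbers. The step of a 1.1-fold higher number from compound 1 to compound 2 (0.04 log units; within the scatter) stays within the scatter, whereas a 3.2-fold higher number from compound 2 to compound 3 (0.51 log units; beyond the scatter) and a 3.5-fold higher number from compound 1 to compound 3 (0.54 log units; beyond the scatter) lie beyond it. Compound 4 `COC(=O)/C=C/c1cccc(N(Cc2ccc(-c3cccc(OC)c3)cc2)C(=O)C(C)C)c1` differs from compound 3 by methyl in place of trifluoromethyl on an oxygen on an aromatic ring. Among the compounds with values here, no measured step swaps trifluoromethyl for methyl on that oxygen; the only step touching this group, a 3.2-fold higher number from compound 2 to compound 3 (0.51 log units; beyond the scatter), raised the number. Compound 4 is therefore expected to show a step of a 1.6-fold lower number from compound 3 to compound 4 (0.22 log units; within the scatter). The estimate for compound 4 in this assay is 150 nM, with a range from 60 nM to 400 nM.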

Compound 4, half-maximal effective concentration: 72 nM
Compound 4: the middle estimate sits 2.1-fold (0.32 log units) above what was measured; the measured number falls inside the stated range.
By their numbers in this assay, from the lowest: compounds 1, 4 and 2 (each within the scatter of the next); then compound 3.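

In this assay, methyl in place of trifluoromethyl on the oxygen gives a 3.4-fold lower number from compound 3 to compound 4 (0.54 log units; beyond the scatter), so the group on this oxygen affects the read-out. Methoxy and chloro cannot be told apart, with a 1.1-fold lower number from compound 2 to compound 4 (0.03 log units; within the scatter), and the same holds for 3-methoxyphenyl and 2-(3-fluorophenyl)ethenyl, with a 1.0-fold higher number from compound 1 to compound 4 (0.01 log units; within the scatter), leaving compound 3 alone at the higher number. No evidence at hand bears on the reason for this difference. From the compounds shown here alone, whether a hydroxy group, an amine, a carboxylic acid or a longer chain such as ethoxy in place of methoxy would stay level with compound 4 or move towards compound 3 remains open.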